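A few compounds are considered here, and "the series" means these few. Any claim that something is new, unique, unknown or untested is made for them only; others in the source may bear on it.

Compound 1 `COc1ccc(C(=O)/C=C/c2cccc([N+](=O)[O-])c2)c2c1C=CC(C)(C)O2` — in a functional assay on SW-620 cells (Homo sapiens) for antiproliferative activity, read by MTT assay, with a stated time of 24 h (a lower number here means a stronger inhibitor, a higher number a weaker inhibitor), compound 1 gives 4090 nM.
Compound 2 `COc1ccc(C(=O)/C=C/c2cccc(C(F)(F)F)c2)c2c1C=CC(C)(C)O2` — in this assay compound 2 gives 7870 nM.

Among the measured compounds shown here, compound 1 holds the lowest of the two numbers measured so far, and its nearest neighbour is compound 2, whose value lies within the scatter of that of compound 1. For the measured compounds named here, the only measured step, a 1.9-fold higher number from compound 1 to compound 2 (0.28 log units; within the scatter), changed the group on the aromatic carbon and left the number essentially where it was.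

Compound 3 `COc1ccccc1/C=C/C(=O)c1ccc(OC)c2c1OC(C)(C)C=C2` has not yet been measured in this assay. It differs from compound 1 by 2-methoxyphenyl in place of 3-nitrophenyl on a double-bonded chain carbon bound to a double-bonded chain carbon. The step from compound 1 to compound 2 is the only one that bears on this change, as it also touched the 3-nitrophenyl, and it was within the scatter. The change to compound 3 is larger, since the whole 3-nitrophenyl is exchanged, so the outcome is less certain, but nothing measured points to a big shift in either direction. Compound 3 is therefore expected to give about 6000 nM, within a range from 2000 nM to 18000 nM. The step this estimate implies, a 1.5-fold higher number from compound 1 to compound 3 (0.17 log units; within the scatter), is expected to stay within the scatter.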

Compound 3, half-maximal inhibitory concentration: > 10000 nM
Compound 3 gave a limit, no number (the forecaster's own chance of this, stated with the estimate: 10%); middle value at least 1.6-fold (0.22 log units) from the limit.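

In this assay, putting 2-methoxyphenyl in place of 3-nitrophenyl on a double-bonded chain carbon bound to a double-bonded chain carbon gave an at least 2.4-fold higher number from compound 1 to compound 3 (0.38 log units; beyond the scatter), so this position can respond to a change beyond the scatter. The earlier step, a 1.9-fold higher number from compound 1 to compound 2 (0.28 log units; within the scatter), had stayed within the scatter, and it exchanged only the nitro group for trifluoromethyl, whereas this change replaces the whole 3-nitrophenyl and so alters both the group and its numbered place on the phenyl ring. The value of compound 3 is a limit of the assay and not a number, so the step gives only a lower bound on the size of the change: the limit of > 10000 nM in this assay, at which 1 of the 3 values shown sits.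

The compounds shown leave open whether the methoxy group itself or its numbered place on the ring accounts for the step, a question that 3-methoxyphenyl would separate. They also leave open how an unsubstituted phenyl, or a phenyl carrying an amine or a carboxylic acid, would compare with compound 1 at this position.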